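Side chain swap on the amino acid quinone series

The source may report more compounds than this note shows. Statements on the series, on what has been measured and on what is new or still open speak of the compounds shown alone.

Measured in a functional assay on Fem-X cells (Homo sapiens) for cytotoxicity, read by MTT assay, with a stated time of 72 h; a higher number here means a weaker inhibitor, a lower number a stronger inhibitor:
- compound 1 `CC(C)(C)C1=CC(=O)C=C(NCC(=O)O)C1=O` gives 34300 nM
- compound 2 `CC1=CCC[C@H]2[C@](C)(CC3=CC(=O)C(N4CCC[C@H]4C(=O)O)=CC3=O)[C@@H](C)CC[C@]12C` gives 39600 nM
- compound 3 `CSCC[C@H](NC1=CC(=O)C=C(C[C@]2(C)[C@@H](C)CC[C@]3(C)C(C)=CCC[C@@H]23)C1=O)C(=O)O` gives 19400 nM

Compound 3 lies within the scatter of compound 1. Its gap to compound 2 lies beyond the scatter, with compound 2 carrying the higher number. Compound 4 `CC1=CCC[C@H]2[C@](C)(CC3=CC(=O)C=C(N[C@@H](C(=O)O)C(C)C)C3=O)[C@@H](C)CC[C@]12C` has not yet been measured. It differs from compound 3 by 1-carboxy-2-methylpropyl in place of 1-carboxy-3-(methylsulfanyl)propyl on an amine nitrogen.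

For the measured compounds named here, no pair of measured compounds differs in one place only, so this assay offers no direct precedent for this change. The expectation rests on the narrow spread of the series, whose ends are compound 3 at 19400 nM and compound 2 at 39600 nM. The expected step, a 1.3-fold higher number from compound 3 to compound 4 (0.11 log units; within the scatter), is a small rise in the number and stays within the scatter. For compound 4 the estimated value is 25000 nM, with an expected range of 12000 nM to 50000 nM.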

Compound 4, half-maximal inhibitory concentration: 11400 nM
Estimate against measurement, compound 4: 2.2-fold (0.34 log units) above; measured number outside the range, below it.
By their numbers in this assay, from the lowest: compounds 4, 3, 1 and 2 (each within the scatter of the next, the first and the last beyond it).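

In this assay the series now has its first comparison that differs in one place only: 1-carboxy-2-methylpropyl in place of 1-carboxy-3-(methylsulfanyl)propyl on an amine nitrogen gives a 1.7-fold lower number from compound 3 to compound 4 (0.23 log units; within the scatter) and so stays within the scatter. At this position, then, the sulfur-bearing side chain can be exchanged for the branched one without a change that can be told from the scatter. Nothing measured here accounts for the step, and no supporting data bear on it.

From the compounds shown here alone, whether this position tolerates side chains of a different kind remains open, for example a benzyl group or a side chain ending in an amine. Also open, going by these compounds, is whether a primary amide in place of the carboxylic acid would move the number beyond the scatter.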